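Moving from a methylphenyl to a trifluoromethylphenyl group

The source may report more compounds than this note shows. Statements on the series, on what has been measured and on what is new or still open speak of the compounds shown alone.

In a functional assay on A549 cells (Homo sapiens) for antiproliferative activity, read by MTT assay, with a stated time of 72 h (a higher number here means a weaker inhibitor, a lower number a stronger inhibitor), compound 3 (`CCCNC(=O)c1cc(Oc2ccc(NC(=O)c3nn(-c4ccccc4C)c(=O)cc3C)cc2F)ccn1`) gives 25700 nM. Compound 1 (`CCNC(=O)c1cc(Oc2ccc(NC(=O)c3nn(-c4ccc(Br)cc4F)c(=O)cc3C)cc2)ccn1`) gives 34500 nM, and compound 2 (`CCCNC(=O)c1cc(Oc2ccc(NC(=O)c3nn(-c4ccc(C)cc4)c(=O)cc3C)cc2F)ccn1`) gives 18000 nM. Compound 3 lies within the usual scatter of both, so these numbers do not set it apart from either one.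

Compound 4 (`CCCNC(=O)c1cc(Oc2ccc(NC(=O)c3nn(-c4cccc(C(F)(F)F)c4)c(=O)cc3C)cc2F)ccn1`) has not yet been measured. It carries 3-(trifluoromethyl)phenyl in place of 2-methylphenyl on an aromatic nitrogen. One measured step involves the same place: 2-methylphenyl in place of 4-methylphenyl gave a 1.4-fold higher number from compound 2 to compound 3 (0.15 log units; within the scatter). Among the compounds with values here, that step is small, but it only compares two methylphenyl groups, and no measured compound carries a trifluoromethyl group, so the guide is limited. On this evidence, no change beyond the scatter is expected in this assay. The expected step is a 1.3-fold lower number from compound 3 to compound 4 (0.11 log units; within the scatter), too small to give a firm direction. For compound 4 the estimated value is 20000 nM, with an expected range of 9000 nM to 42000 nM.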

Compound 4, half-maximal inhibitory concentration: 9240 nM
For compound 4 the middle estimate is 2.2-fold (0.34 log units) above the measured one; measured number inside the range.
By their numbers in this assay, from the lowest: compounds 4, 2, 3 and 1 (each within the scatter of the next, the first and the last beyond it).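

In this assay, the group on the aromatic nitrogen can move the number beyond the scatter, which the two methylphenyl groups alone did not show: 3-(trifluoromethyl)phenyl in place of 2-methylphenyl gives a 2.8-fold lower number from compound 3 to compound 4 (0.44 log units; beyond the scatter) as a modest step. The same group in place of 4-methylphenyl gives a 1.9-fold lower number from compound 2 to compound 4 (0.29 log units; within the scatter) and stays within the scatter, so the clear difference holds only against the 2-methylphenyl compound. The step from compound 3 changes both the group and where it sits on the phenyl ring, and these two changes cannot be separated here.

Still open, as far as these compounds go, is how a phenyl ring carrying an amine or a carboxylic acid would behave at this position. The data shown also offer no measurement that explains the step.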